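The source may hold more compounds than are shown below. What is called first, only, known or untested is meant among the compounds shown, and "the series" means these compounds.

Measured compounds in an ADME assay on MOLT-3 cells (Homo sapiens) for cytotoxicity, with a stated time of 7 days; on this read-out higher numbers stand for lower toxicity in this test and lower numbers for higher toxicity in this test:
Compound 1, `CCCSc1nc(N)nc2c1ncn2/C=C1/CC1(CO)CO`, gives > 20000 nM, which is a limit of this assay.
Compound 2, `CC(C)Nc1nc(N)nc2c1ncn2/C=C1/CC1(CO)CO`, gives "not determined" (no result reported).
Compound 3, `Nc1nc(NC2CCCC2)c2ncn(/C=C3/CC3(CO)CO)c2n1`, gives > 20000 nM, which is again a limit of this assay.

Compound 1 therefore stands only at a limit in this assay, with no single number for it. For the measured compounds named here, the one measured step that changes one place, a step that the two limits leave unreadable from compound 1 to compound 3, is likewise unreadable in size because both ends rest on (the limit of > 20000 nM in this assay, at which 2 of the 3 values shown sit). Compound 2 adds nothing here.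

Compound 4, `CCCCCCOc1nc(N)nc2c1ncn2/C=C1/CC1(CO)CO`, is not yet measured. Compared with compound 1 it carries hexyloxy in place of propylsulfanyl on an aromatic carbon.

Going by the values given here, no measured step bears directly on this change, and the single step from compound 1 to compound 3 gives no readable size. What the two limits show is that compound 1 and compound 3 sit at the same limit of this assay. Compound 4 is expected to behave like them, so the estimated step that the limit leaves unreadable from compound 1 to compound 4 should be none beyond the scatter. Compound 4 is thus estimated at 40000 nM, with a range from 15000 nM to 150000 nM, most likely reported again only as a limit.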

Compound 4, half-maximal cytotoxic concentration: > 20000 nM
Compound 4: only a limit was reported; the forecaster's own chance of this, stated with the estimate: 85%; the middle value does not contradict the limit.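

No step among compound 1, compound 3 and compound 4 can be read in this assay, since each gives only a limit: the limit of > 20000 nM in this assay, at which 3 of the 4 values shown sit.

The compounds shown leave open at what concentration any of them turns cytotoxic, and whether propylsulfanyl, cyclopentylamino and hexyloxy differ at all in this assay.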